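Chloro in place of tert-butyl on the benzoate ester

The source may report more compounds than this note shows. Statements on the series, on what has been measured and on what is new or still open speak of the compounds shown alone.

Compound 1 `Clc1ccc2c(-n3cc(C4CCCCC4)nn3)ccnc2c1` gives > 3200 nM in an ADME assay on HepG2 cells (Homo sapiens) for cytotoxicity, read by MTT assay, with a stated time of 24 h (on this read-out lower numbers stand for higher toxicity in this test and higher numbers for lower toxicity in this test), which is a limit of the assay.
Compound 2 `CC(C)(C)c1ccc(C(=O)OCc2cn(-c3ccnc4cc(Cl)ccc34)nn2)cc1` gives > 2380000 nM in this assay, likewise a limit of the assay.

Compound 2 therefore stands at a limit in this assay, being one of the values that sit at the limit of > 2380000 nM in this assay, at which 1 of the 2 values shown sits. The other value shown, that of compound 1, is also a limit, sitting at the limit of > 3200 nM in this assay, at which 1 of the 2 values shown sits. Compound 3 `O=C(OCc1cn(-c2ccnc3cc(Cl)ccc23)nn1)c1ccc(Cl)cc1` differs from compound 2 by chloro in place of tert-butyl on an aromatic carbon. For the measured compounds named here, no step between two measured compounds exists to gauge this change, and both measured values are limits rather than numbers. The step expected is an at least 1.1-fold lower number from compound 2 to compound 3 (0.07 log units; that floor lies within the scatter), that is, none beyond the scatter. Compound 3 is accordingly estimated at 2000000 nM in this assay, with a range from 400000 nM to 5000000 nM, and most probably it will again be reported only as a limit.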

Compound 3, half-maximal cytotoxic concentration: 484000 nM
The estimate for compound 3 lay 4.1-fold (0.62 log units) above the measured number; measured number inside the range.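

Compound 3 is the only compound shown that carries a number rather than a limit in this assay, which gives this position its first actual reading. Chloro in place of tert-butyl on an aromatic carbon gives an at least 4.9-fold lower number from compound 2 to compound 3 (0.69 log units; beyond the scatter), showing that the read-out responds to this change, in the direction of higher toxicity in this test. The true size of the step stays open, as compound 2 stands at a limit of the assay: the limit of > 2380000 nM in this assay, at which 1 of the 3 values shown sits.

The compounds shown leave open whether the step follows from the loss of tert-butyl or the arrival of chloro, and how a bare hydrogen, a methoxy group or an amine at the same place would read in this assay. Compound 1 differs from both others in more than one place and offers no comparison.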